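Swapping a chloromethyl for a but-1-en-1-yl on the amide

A few compounds are considered here, and "the series" means these few. Any claim that something is new, unique, unknown or untested is made for them only; others in the source may bear on it.

For the measured compounds named here, compound 1 `COc1ccc(CN(C(=O)CCl)c2cc(OC)c(OC)c(OC)c2)cc1O` gives 84 nM in a functional assay on MGC-803 cells (Homo sapiens) for inhibition, read by MTT assay, with a stated time of 48 h (a lower number here means a stronger inhibitor, a higher number a weaker inhibitor), the lowest of the two numbers known here. Compound 2 `COc1ccc(CNc2cc(OC)c(OC)c(OC)c2)cc1N` gives 7970 nM in this assay, a gap well beyond the scatter. Compound 3 `CC/C=C/C(=O)N(Cc1ccc(OC)c(O)c1)c1cc(OC)c(OC)c(OC)c1` differs from compound 1 in one place: but-1-en-1-yl in place of chloromethyl on a carbonyl carbon. Going by the values given here, no measured pair shows this change, so its effect is uncertain. Compound 3 is expected to give 400 nM, within 120 nM to 1500 nM. The expected step of a 4.8-fold higher number from compound 1 to compound 3 (0.68 log units; beyond the scatter) is toward a higher number, modest but beyond the scatter.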

Compound 3, half-maximal inhibitory concentration: 58 nM
Beside the measured number, compound 3's estimate is 6.9-fold (0.84 log units) above it, outside the stated range (below it).
By their numbers in this assay, from the lowest: compounds 3 and 1 (each within the scatter of the next); then compound 2.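

Putting but-1-en-1-yl in place of chloromethyl on a carbonyl carbon gives a 1.4-fold lower number from compound 1 to compound 3 (0.16 log units; within the scatter) in this assay and so the two compounds stand level. This place on the core therefore accepts a longer chain with a double bond and no chlorine, so chlorine is not needed here for a value of this size. Nothing available bears on why the two groups read alike.

On these data alone, whether a saturated butyl chain or a phenyl ring on the same carbonyl carbon would read the same stays open. So does the part the double bond plays in compound 3.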